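The source may hold more compounds than are shown below. What is called first, only, known or untested is meant among the compounds shown, and "the series" means these compounds.

Working notes on the series. Compound 1 `CCN(CC)CCNC(=O)C1CN(S(=O)(=O)c2ccc(OC)c3ccccc23)c2ccccc21` and compound 2 `CN1CCC(N(C)C(=O)C2CN(S(=O)(=O)c3cccc4c(Cl)cccc34)c3ccccc32)CC1` share the same core and differ in the group on the sulfonyl sulfur and in the amide side chain. In a functional assay on CHO cells for antagonist activity at 5-hydroxytryptamine receptor 6 (Homo sapiens), read by FLIPR (a higher number here means a weaker inhibitor, a lower number a stronger inhibitor), compound 1 gives 20 nM, and in this assay compound 2 gives 5.01 nM, the lower of the two numbers; the gap between them lies beyond the usual scatter, so compound 2 is the stronger inhibitor of the pair. For the measured compounds named here, no single-change step between measured compounds is available.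

Compound 3 `CN1CCC(N(C)C(=O)C2CN(S(=O)(=O)c3ccccc3)c3ccccc32)CC1` is the next compound to be measured. Compared with compound 2, the change is phenyl in place of 5-chloronaphthalen-1-yl on a sulfonyl sulfur; the amide side chain is kept. Nothing measured here shows how this exchange plays out, so the expectation rests on the general trend that a smaller aryl group on the sulfonyl usually gives a weaker inhibitor. Compound 3 is expected to give a step of a 10-fold higher number from compound 2 to compound 3 (1.00 log units; beyond the scatter) toward a higher number. The estimate for compound 3 in this assay is 50 nM, with a range from 10 nM to 250 nM.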

Compound 3, inhibition constant: 316 nM
The estimate for compound 3 lay 6.3-fold (0.80 log units) below the measured number; the whole stated range lies below it.
By their numbers in this assay, from the lowest: compound 2; then compound 1; then compound 3.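

With the amide side chain kept, phenyl in place of 5-chloronaphthalen-1-yl on a sulfonyl sulfur gives a 63-fold higher number from compound 2 to compound 3 (1.80 log units; beyond the scatter) in this assay. For the compounds shown here, this is the only single-change step so far, and it shows that the group at this position strongly affects the read-out, with the larger group giving the lower number. The exchange removes one aromatic ring and the chlorine together, and no measurement at hand gives a reason for the size of the step.

Open, as far as these compounds go, is how much of the step belongs to the second ring and how much to the chlorine, which plain naphthalen-1-yl and a chlorophenyl group would separate. Also open, from the compounds shown here alone, is whether the exchange behaves the same way with the diethylaminoethyl amide side chain of compound 1.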